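A few compounds are considered here, and "the series" means these few. Any claim that something is new, unique, unknown or untested is made for them only; others in the source may bear on it.

For the measured compounds named here, in a functional assay (muscle tissue) with Cavia porcellus as the target (a lower number here means that less compound is needed, a higher number that more compound is needed for the effect), compound 2 `COC(=O)C1=C(C)N=C(C)/C(=C(\O)OC)C1c1cccc(C(F)(F)F)c1`, at 74.1 nM, holds the lowest number so far, and compound 1 `COC(=O)C1=C(C)N=C(C)/C(=C(\O)OC)C1c1cccc(OC)c1` gives 191 nM. Compound 3 `COC(=O)C1=C(C)N=C(C)/C(=C(\O)OC)C1c1cccc(OC(=O)c2ccccc2)c1` carries benzoyloxy in place of the trifluoromethyl of compound 2, on an aromatic carbon: benzoyloxy in place of trifluoromethyl on an aromatic carbon. Going by the values given here, only one measured step bears on this place, a 2.6-fold lower number from compound 1 to compound 2 (0.41 log units; beyond the scatter). It is modest, beyond the scatter, and involves a different exchange, so it offers a scale rather than a direct guide. A modest move to a higher number is expected in this assay, as a 2.4-fold higher number from compound 2 to compound 3 (0.39 log units; beyond the scatter). Compound 3 is estimated at 180 nM, with an expected range of 40 nM to 800 nM.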

Compound 3, half-maximal effective concentration: 6310 nM
For compound 3 the middle estimate is 35-fold (1.54 log units) below the measured one, outside the stated range (above it).
By their numbers in this assay, from the lowest: compound 2; then compound 1; then compound 3.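

In this assay, this position proves far more sensitive than the earlier pair indicated: against the modest 2.6-fold lower number from compound 1 to compound 2 (0.41 log units; beyond the scatter), the new exchange gives an 85-fold higher number from compound 2 to compound 3 (1.93 log units; beyond the scatter). Compound 1 and compound 3 both keep an oxygen on the aromatic ring, yet benzoyl in place of methyl on that oxygen still gives a 33-fold higher number from compound 1 to compound 3 (1.52 log units; beyond the scatter), so that oxygen alone does not set the high number. No measured property accounts for these rises.

As far as these compounds go, whether the aromatic ring or the carbonyl of benzoyloxy goes with the rise remains open. Acetyloxy or benzyloxy at this position would separate the two.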